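The compounds below may be only part of what the source reports. "The series", "measured", "known", "first", "only" and "open" are said of these compounds alone.

Measured in a functional assay on U2OS cells (Homo sapiens) for antiproliferative activity, read by MTT assay, with a stated time of 72 h; on this read-out higher numbers stand for weaker inhibition and lower numbers for stronger inhibition:

Compound 1 `O=C(Cn1cc(F)c(=O)n(CC(=O)Nc2ccc(Br)cn2)c1=O)Nc1ccc(Br)cn1`: 5140 nM.
Compound 2 `O=C(CSc1cccc(O)c1)Nc1ccc2nc(NC(=O)c3ccc(F)cc3)sc2c1`: 5120 nM.
Compound 3 `O=C(CSc1nnc(NC(=O)COc2ccccc2)s1)Nc1ccc(Br)cc1`: > 100000 nM, a limit and not a number.

Compound 3 sits at the limit of > 100000 nM in this assay, at which 1 of the 3 values shown sits. By contrast, compound 1 gives 5140 nM and compound 2 gives 5120 nM, two numbers within the usual scatter of each other.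

Compound 4 `COc1ccc(C(=O)Nc2nnc(SCC(=O)Nc3ccc(Br)cc3)s2)cc1OC` keeps most of the structure of compound 3 and changes one group: 3,4-dimethoxyphenyl in place of phenoxymethyl on a carbonyl carbon. In plain terms, 3,4-dimethoxyphenyl takes the place of phenoxymethyl on a carbonyl carbon. Among the measured compounds shown here, no pair of measured compounds here differs in one place, so nothing yet shows directly what this swap does.

The expectation therefore has little to rest on. Compound 3 has only the limit > 100000 nM, so any measurable result for compound 4 would be a move toward stronger inhibition in this assay. A moderate move is expected, and compound 4 may well stay at the limit. The estimated change is an at least 3.3-fold lower number from compound 3 to compound 4 (0.52 log units; beyond the scatter). For compound 4 the expected value is 30000 nM, with an estimated range from 6000 nM to 100000 nM.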

Compound 4, half-maximal inhibitory concentration: > 100000 nM
Compound 4 was reported as a limit; the forecaster's own chance of this, stated with the estimate: 35%; at least 3.3-fold (0.52 log units) between middle value and limit.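

Compound 3 and compound 4 are both reported only as a limit and not as a number, so no step can be read between them: the limit of > 100000 nM in this assay, at which 2 of the 4 values shown sit.

From the compounds shown here alone, whether 3,4-dimethoxyphenyl in place of phenoxymethyl on a carbonyl carbon changes inhibition at all in this assay stays open, as does which change to compound 3 would give a measurable number.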